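This account rests on a few compounds, and the source may have more. Where it says the series, first, only, none or still open, it means among the compounds named here.

Compound 1 `Cc1ccc(Oc2cccc(CN3CCC(n4cc(C)c(=O)[nH]c4=O)CC3)c2)cc1`; compound 2 `Cc1cn(C2CCN(Cc3cccc(Oc4ccc(Cl)cc4)c3)CC2)c(=O)[nH]c1=O`; compound 3 `Cc1cn(C2CCN(Cc3cccc(Oc4ccncc4)c3)CC2)c(=O)[nH]c1=O`.

In an ADME assay on MRC5 cells (Homo sapiens) for cytotoxicity, read by fluorescence and resazurin assay, with a stated time of 3 days (a lower number here means a stronger inhibitor, a higher number a weaker inhibitor), compound 1 gives only a limit of the assay, > 64000 nM. Compound 2 gives 25100 nM in this assay. Compound 3, with the same core, gives "not determined" (no result reported) in this assay, so no number places it among the others. Compound 4 `Cc1cn(C2CCN(Cc3cccc(Oc4ccccn4)c3)CC2)c(=O)[nH]c1=O` differs from compound 3 by pyridin-2-yl in place of pyridin-4-yl on an oxygen on an aromatic ring. Among the measured compounds shown here, the one measured step, an at least 2.5-fold lower number from compound 1 to compound 2 (0.40 log units; beyond the scatter), concerns a different change and does not bear on this one; no measured step covers the move from compound 3 to compound 4. No step beyond the scatter is therefore expected, and a limit remains likely. Compound 4 is estimated at 60000 nM, within 20000 nM to 200000 nM.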

Compound 4, half-maximal inhibitory concentration: > 64000 nM
Compound 4: only a limit was reported (the forecaster's own chance of this, stated with the estimate: 60%); at least 1.0-fold (0.02 log units) between middle value and limit.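

On an oxygen on an aromatic ring, pyridin-2-yl in place of 4-chlorophenyl gives an at least 2.5-fold higher number from compound 2 to compound 4 (0.40 log units; beyond the scatter) in this assay, so a ring with a nitrogen can also move the result away from that of compound 2. Compound 4 gives > 64000 nM, which is a limit of the assay and not a number. The step from compound 1 to compound 4 cannot be read, and both compounds sit at one limit: the limit of > 64000 nM in this assay, at which 2 of the 4 values shown sit.

Compound 3 has no result, which leaves pyridin-4-yl against pyridin-2-yl open. Also open, from the compounds shown here alone, is how a phenyl ring carrying an amine or a carboxylic acid would read here.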